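The source may report more compounds than this note shows. Statements on the series, on what has been measured and on what is new or still open speak of the compounds shown alone.

Measured compounds: compound 1 `Cc1c(Nc2nc(N)c3c(C#N)c(N4CCC[C@H]4C)n(C)c3n2)cnn1C`, 260 nM; compound 2 `Cc1c(Nc2nc(N)c3c(C#N)c(N4CCC[C@H]4C)n(C)c3n2)cnn1CC1(O)COC1`, 120 nM; compound 3 `Cc1c(Nc2nc(N)c3c(C#N)c(N4CCC[C@H]4C)n(C)c3n2)cnn1C1COC1`, 190 nM.

In an assay on HEK293 cells for inhibition of Leucine-rich repeat serine/threonine-protein kinase 2 variant G2019S (Homo sapiens), with a stated time of 48 h (a lower number here means a stronger inhibitor, a higher number a weaker inhibitor), compound 3 stands second highest of the three numbers; its gaps to compound 1 and to compound 2 both lie within the scatter, so no order among the three is claimed. Compound 4 `Cc1c(Nc2nc(N)c3c(C#N)c(N4CCC[C@H]4C)n(C)c3n2)cnn1CC(C)(C)O` differs from compound 3 by 2-hydroxy-2-methylpropyl in place of oxetan-3-yl on an aromatic nitrogen. The bearing steps: a 2.2-fold lower number from compound 1 to compound 2 (0.34 log units; beyond the scatter), where a 3-hydroxyoxetan-3-yl enters, and a 1.6-fold higher number from compound 2 to compound 3 (0.20 log units; within the scatter). The entering group of compound 4, like that of compound 2, carries one hydrogen-bond donor; the measured steps suggest at most a modest downward shift or none beyond the scatter. Compound 4 is therefore expected to give 140 nM (range 65 nM to 300 nM), a step of a 1.4-fold lower number from compound 3 to compound 4 (0.13 log units; within the scatter).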

Compound 4, half-maximal inhibitory concentration: 120 nM
For compound 4 the middle estimate is 1.2-fold (0.07 log units) above the measured one, within the range that was stated.
By their numbers in this assay, from the lowest: compounds 2, 4, 3 and 1 (each within the scatter of the next, the first and the last beyond it).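

In this assay the open-chain 2-hydroxy-2-methylpropyl matches the ring-bearing group of compound 2, with no change at the digits printed from compound 2 to compound 4 (within the scatter) and with a 2.2-fold lower number from compound 1 to compound 4 (0.34 log units; beyond the scatter) so that on this aromatic nitrogen a four-membered ring is not needed for a step beyond the scatter. Against oxetan-3-yl, which has no hydrogen-bond donor, the result is a 1.6-fold lower number from compound 3 to compound 4 (0.20 log units; within the scatter) and does not separate the two groups. No measurement at hand accounts for these numbers. Still open, as far as these compounds go, is how an amine, a carboxylic acid or a longer chain ending in hydroxyl would read on this nitrogen, and whether an open chain without hydroxyl, such as isobutyl, keeps the step from compound 1.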